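The source may report more compounds than this note shows. Statements on the series, on what has been measured and on what is new or still open speak of the compounds shown alone.

Of the compounds shown here, two have been measured so far, both carrying a chloro group on the shared core and a benzyl arm that ends in a chloromethyl group. Compound 1 `ClCc1ccc(Cn2cnc3c(Cl)ncnc32)cc1` is one of them. In a functional assay on K562 cells (Homo sapiens) for cytotoxicity, read by sulforhodamine B assay, with a stated time of 48 h (a higher number here means a weaker inhibitor of growth, a lower number a stronger inhibitor of growth), compound 1 gives 2910 nM. Compound 2 `ClCc1ccccc1Cn1cnc2ncnc(Cl)c21`, in which the chloromethyl group sits at a different position of the benzyl ring, gives 2230 nM in this assay. For the measured compounds named here, of the two numbers, the one for compound 1 is the higher, but the gap to compound 2 lies within the usual scatter, so the two compounds cannot be told apart on these data.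

Compound 3 `ClCc1ccc(Cn2cnc3c(Cl)nc(Cl)nc32)cc1` has not yet been measured. Relative to compound 1 it differs in one place: chloro in place of hydrogen on an aromatic carbon. Going by the values given here, no step of this kind exists between the measured compounds, so there is nothing to calibrate against. Adding a single chloro group is a small change, and the expectation is that it moves the number little, in either direction, or not beyond the scatter at all. The expected step is a 1.2-fold lower number from compound 1 to compound 3 (0.07 log units; within the scatter). Compound 3 is therefore estimated at about 2500 nM, with a plausible range from 900 nM to 7000 nM.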

Compound 3, concentration for 50% growth inhibition: 23400 nM
Compound 3: the middle estimate sits 9.4-fold (0.97 log units) below what was measured; the whole stated range lies below it.
By their numbers in this assay, from the lowest: compounds 2 and 1 (each within the scatter of the next); then compound 3.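

In this assay, chloro in place of hydrogen on the aromatic carbon between two ring nitrogen atoms gives an 8.0-fold higher number from compound 1 to compound 3 (0.91 log units; beyond the scatter), so a change of a single heavy atom at this position is enough to weaken growth inhibition beyond the scatter. Until now, the only comparison was between compound 1 and compound 2, whose numbers could not be told apart, so this is the first clear separation among the compounds shown, and it comes from the shared core rather than the benzyl arm. Nothing available bears on what lies behind this step, which therefore stands as an observation only.

As far as these compounds go, it remains open whether the weaker growth inhibition is specific to chloro or would also appear with another group on this carbon, such as an amine, a methoxy group or a methyl group. For the compounds shown here, it is also open whether the same change would have a step of similar size with the chloromethyl group placed as in compound 2, since this step has been read in only one compound pair.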